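The compounds below may be only part of what the source reports. "The series", "measured", "known", "first", "only" and "open" are said of these compounds alone.

Of the compounds shown here, two of a shared core have been measured so far. Compound 1 `CCCCCCCCNc1nc(SCc2ccc(C(F)(F)F)cc2)nc2ccccc12` gives 12600 nM in a functional assay on MGC-803 cells (Homo sapiens) for cytotoxicity, read by MTT assay, with a stated time of 72 h; on this read-out higher numbers stand for weaker inhibition and lower numbers for stronger inhibition. Compound 2 `FC(F)(F)c1ccc(CSc2nc(Nc3cccc(Cl)c3)c3ccccc3n2)cc1` gives 14600 nM in this assay, the highest of the two numbers; its nearest neighbour is compound 1, and the step of a 1.2-fold higher number from compound 1 to compound 2 (0.06 log units; within the scatter) lies within the scatter, so the two values cannot be ordered.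

Compound 3 `COc1ccc(Nc2nc(SCc3ccc(C(F)(F)F)cc3)nc3ccccc23)c(OC)c1` has not yet been measured in this assay. It differs from compound 2 by 2,4-dimethoxyphenyl in place of 3-chlorophenyl on a nitrogen on an aromatic ring.

Within the data shown here, only one measured step bears on this change, since it is the only one that alters the group on that same nitrogen on an aromatic ring: a 1.2-fold higher number from compound 1 to compound 2 (0.06 log units; within the scatter), where an octyl chain gave way to a 3-chlorophenyl ring and the number hardly moved. With a second aryl group entering at the same place, no step beyond the scatter is expected, and the estimated step is a 1.0-fold lower number from compound 2 to compound 3 (0.02 log units; within the scatter).

For compound 3 the expected value in this assay is therefore 14000 nM, with a range from 6000 nM to 35000 nM.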

Compound 3, half-maximal inhibitory concentration: > 50000 nM
Compound 3 was reported as a limit (the forecaster's own chance of this, stated with the estimate: 15%); middle value at least 3.5-fold (0.55 log units) from the limit.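

At the nitrogen on an aromatic ring, the group now makes a difference in this assay: the step of an at least 3.4-fold higher number from compound 2 to compound 3 (0.53 log units; beyond the scatter) lies beyond the scatter, and so does the step of an at least 3.9-fold higher number from compound 1 to compound 3 (0.59 log units; beyond the scatter), whereas octyl and 3-chlorophenyl could not be ordered. An aryl group at this place therefore does not by itself hold the value seen for compound 2, since 2,4-dimethoxyphenyl and 3-chlorophenyl, both carried on that nitrogen, do not behave alike. Compound 3 stands at a limit and not at a number, so both steps give only a lower bound on the size of the change: the limit of > 50000 nM in this assay, at which 1 of the 3 values shown sits.

The compounds shown do not separate the loss of the chlorine from the entry of the two methoxy groups, and they do not say why the change matters, so a phenyl ring carrying a single methoxy group, or an unsubstituted phenyl ring, remains an open case. They also leave open whether an amine on that ring, or a shorter chain in place of octyl, would give a lower number than compound 1 or compound 2 in this assay.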